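The compounds below may be only part of what the source reports. "The series", "measured", "known", "first", "only" and "open" are said of these compounds alone.

Measured so far:
compound 1 `COc1cc(-c2nn(-c3cccc(NC(=O)Nc4cc(C(F)(F)F)cc(C(F)(F)F)c4)c3)cc2-c2ccncc2)ccc1Cl` — > 50000 nM
compound 2 `COc1cc(-c2nn(-c3cccc(NC(=O)Nc4ccc(Cl)c(Cl)c4)c3)cc2-c2ccncc2)ccc1Cl` — > 50000 nM

In a functional assay on OVCAR-8 cells (Homo sapiens) for inhibition, read by sulforhodamine B assay, with a stated time of 48 h (on this read-out lower numbers stand for higher toxicity in this test and higher numbers for lower toxicity in this test), compound 1 gives > 50000 nM, which is a limit of the assay and not a number. Compound 2 likewise reaches only > 50000 nM in this assay, again a limit. Compound 1 therefore stands at the ceiling of what has been measured, with no value in the series resolved to a number; (the limit of > 50000 nM in this assay, at which 2 of the 2 values shown sit). Going by the values given here, no step between measured compounds can be sized.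

Compound 3 `COc1cc(-c2nn(-c3cccc(NC(=O)Nc4cccc(C(F)(F)F)c4)c3)cc2-c2ccncc2)ccc1Cl` differs from compound 1 by hydrogen in place of trifluoromethyl on an aromatic carbon. With both measured compounds sitting at the limit, the direction cannot be drawn from them; no step beyond the scatter is expected, and a further limit is the most likely outcome. Compound 3 is expected near 60000 nM, between 25000 nM and 150000 nM. Expected is a step that the limit leaves unreadable from compound 1 to compound 3, nothing beyond the scatter.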

Compound 3, concentration lethal to 50% of the cells: > 50000 nM
Compound 3 was reported as a limit (the forecaster's own chance of this, stated with the estimate: 75%); the middle value lies beyond the limit too.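

No step can be read from compound 1 or compound 2 to compound 3 in this assay, because all three compounds give only a limit of the assay: the limit of > 50000 nM in this assay, at which 3 of the 3 values shown sit. The compounds shown leave open whether any of them has a resolved value in this read-out, and whether their differing substituents separate them at all.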